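Cyclohexyl to Isopropyl on the Amide Carbonyl

This account rests on a few compounds, and the source may have more. Where it says the series, first, only, none or still open, it means among the compounds named here.

Three compounds share one core. Within the data shown here, compound 1 `COC(=O)/C=C/c1cccc(N(Cc2ccc(/C=C/c3c(Cl)cccc3Cl)cc2)C(=O)C(C)C)c1` gives 195 nM in an assay on isolated protein with Bile acid receptor (Homo sapiens) as the target (a higher number here means that more compound is needed for the effect, a lower number that less compound is needed), and compound 2 `COC(=O)/C=C/c1cccc(N(Cc2ccc(/C=C/c3c(F)cccc3F)cc2)C(=O)C(C)C)c1` gives 108 nM; the one measured step, a 1.8-fold lower number from compound 1 to compound 2 (0.26 log units; within the scatter), is small. Compound 3 `COC(=O)/C=C/c1cccc(N(Cc2ccc(/C=C/c3ccccn3)cc2)C(=O)C2CCCCC2)c1` gives 309 nM, the highest of the three numbers, close to compound 1 and further from compound 2. Compound 4 `COC(=O)/C=C/c1cccc(N(Cc2ccc(/C=C/c3ccccn3)cc2)C(=O)C(C)C)c1` differs from compound 3 by isopropyl in place of cyclohexyl on a carbonyl carbon. Among the measured compounds shown here, no measured step touches that position: the only step recorded concerns the halogenated ring, and compounds 1 and 2 carry the isopropyl but differ from compound 3 elsewhere as well, so their values show only that isopropyl amides sit at similar levels. The step of a 1.2-fold lower number from compound 3 to compound 4 (0.09 log units; within the scatter) is therefore expected to stay small, and compound 4 is estimated at 250 nM, within 100 nM to 600 nM.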

Compound 4, half-maximal effective concentration: 310 nM
For compound 4 the middle estimate is 1.2-fold (0.09 log units) below the measured one; the range from low to high includes it.
By their numbers in this assay, from the lowest: compounds 2, 1, 3 and 4 (each within the scatter of the next, the first and the last beyond it).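

In this assay the change to isopropyl on a carbonyl carbon now has its own measured step (a 1.0-fold higher number from compound 3 to compound 4 (0.00 log units; within the scatter)), which shows that cyclohexyl can give way to isopropyl here with the pyridin-2-yl group held fixed. With isopropyl held fixed, pyridin-2-yl can also be read against both halogenated rings: the step from 2,6-difluorophenyl (a 2.9-fold higher number from compound 2 to compound 4 (0.46 log units; beyond the scatter)) lies beyond the scatter, and the step from 2,6-dichlorophenyl (a 1.6-fold higher number from compound 1 to compound 4 (0.20 log units; within the scatter)) lies within it. No evidence offered here accounts for these steps. The compounds shown leave open whether the cyclohexyl-to-isopropyl result also holds with either halogenated ring, and how a longer chain or an amine on that carbonyl carbon would read.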